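Amine Tail Changes and Measured Lipophilicity

A few compounds are considered here, and "the series" means these few. Any claim that something is new, unique, unknown or untested is made for them only; others in the source may bear on it.

compound 1 `COc1cc(/C=C/C(=O)Nc2ccccc2)ccc1OCCCCCN1CCCC1` 1.64
compound 2 `COc1cc(/C=C/C(=O)Nc2ccccc2)ccc1OCCCCCCCCN(C)C` 1.74

In a physicochemical assay for lipophilicity, using the shake flask method, measured as octanol-water partition, at pH 7.4 (a higher number here means a more lipophilic compound, a lower number a more polar compound), compound 1 gives 1.64 and compound 2 gives 1.74; the two stand within the scatter of each other, with a number 0.10 log units higher from compound 1 to compound 2 (within the scatter). Compound 3 `CCN(CC)CCCCCCCCCCOc1ccc(/C=C/C(=O)Nc2ccccc2)cc1OC` differs from compound 2 by 2-(diethylamino)ethyl in place of dimethylamino on a saturated chain carbon, eight bonds along the chain from an oxygen on an aromatic ring. Among the compounds with values here, only this one measured step bears on the change, and it stayed within the scatter; the present change, however, brings in more heavy atoms than it removes, so a modest rise in this assay is expected. For compound 3 the expected step is a number 0.56 log units higher from compound 2 to compound 3 (beyond the scatter). Compound 3 is estimated at 2.3, with a range from 1.9 to 2.8.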

Compound 3, partition coefficient: 1.83
Compound 3: the middle estimate sits 0.47 log units above what was measured, outside the stated range (below it).
By their numbers in this assay, from the lowest: compounds 1, 2 and 3 (each within the scatter of the next).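

In this assay the change to 2-(diethylamino)ethyl in place of dimethylamino, on a saturated chain carbon, eight bonds along the chain from an oxygen on an aromatic ring, gives a number 0.09 log units higher from compound 2 to compound 3 (within the scatter) even though the entering group holds 7 heavy atoms against 3. The wider replacement of pyrrolidin-1-yl by 5-(diethylamino)pentyl gives a number 0.19 log units higher from compound 1 to compound 3 (within the scatter) and so also leaves the two compounds indistinguishable. No evidence here accounts for this result. Going by these compounds, whether a carboxylic acid or a morpholine at the chain end would stay within the same scatter remains open.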